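The source may hold more compounds than are shown below. What is called first, only, known or untested is meant among the compounds shown, and "the series" means these compounds.

In a functional assay on MCF7 cells (Homo sapiens) for inhibition, read by MTT assay, with a stated time of 48 h (on this read-out higher numbers stand for weaker inhibition of growth and lower numbers for stronger inhibition of growth), compound 1 `Cn1cc(C2CC(c3ccccc3)=NN2C(=O)c2cccnc2)c2ccccc21` gives 7200 nM, compound 2 `Cn1cc(C2CC(c3ccccc3)=NN2C(=O)c2cccnc2)c2cc(Br)ccc21` gives 1520 nM and compound 3 `Cn1cc(C2CC(c3ccc(Br)cc3)=NN2C(=O)c2cccnc2)c2cc(Br)ccc21` gives 11800 nM. Compound 2 therefore has the lowest number of the three. Compound 4 `COc1ccc2c(c1)c(C1CC(c3ccccc3)=NN1C(=O)c1cccnc1)cn2C` carries methoxy in place of bromo on an aromatic carbon. The closest evidence is a 4.7-fold lower number from compound 1 to compound 2 (0.68 log units; beyond the scatter), where bromo replaced hydrogen on that same carbon, a modest step beyond the scatter. The step of a 7.8-fold higher number from compound 2 to compound 3 (0.89 log units; beyond the scatter), also modest, shows that adding bromo elsewhere can instead raise the number. Among the compounds with values here, no measured compound carries methoxy, so the expectation is uncertain. In this assay, a modest rise is expected, an estimated 2.3-fold higher number from compound 2 to compound 4 (0.36 log units; beyond the scatter). Compound 4 is estimated at 3500 nM, with an expected range of 1200 nM to 10000 nM.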

Compound 4, concentration for 50% growth inhibition: 1160 nM
Compound 4: middle estimate off by 3.0-fold (0.48 log units), on the high side; measured number below the stated range.
By their numbers in this assay, from the lowest: compounds 4 and 2 (each within the scatter of the next); then compounds 1 and 3 (each within the scatter of the next).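

In this assay, putting methoxy in place of bromo on this aromatic carbon leaves the number within the scatter (a 1.3-fold lower number from compound 2 to compound 4 (0.12 log units; within the scatter)), so the two groups cannot be told apart here. Methoxy in place of hydrogen gives a clear drop (a 6.2-fold lower number from compound 1 to compound 4 (0.79 log units; beyond the scatter)), which shows that the gain on this carbon is not confined to bromo. No measurement here explains why the two groups give such similar numbers.

From the compounds shown here alone, whether an amine or a hydroxyl group on this carbon would keep the number as low remains open. Also open, going by these compounds, is whether methoxy would raise the number where the second bromo of compound 3 sits.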